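From Iodo to tert-Butyl on the Shared Core

The compounds below may be only part of what the source reports. "The series", "measured", "known", "first", "only" and "open" are said of these compounds alone.

Compound 1 `O=C(CCc1cccc2c1B(O)OC2)Nc1ccc(Cl)cc1`: 12000 nM
Compound 2 `O=C(CCc1cccc2c1B(O)OC2)Nc1ccc(I)cc1`: 50000 nM

In a functional assay on HCT-116 cells (Homo sapiens) for antiproliferative activity, read by MTT assay, with a stated time of 72 h (a higher number here means a weaker inhibitor, a lower number a stronger inhibitor), compound 2 gives 50000 nM, the higher of the two numbers. Compound 3 `CC(C)(C)c1ccc(NC(=O)CCc2cccc3c2B(O)OC3)cc1` has tert-butyl in place of iodo on an aromatic carbon. Going by the values given here, one measured step bears on this position: a 4.2-fold higher number from compound 1 to compound 2 (0.62 log units; beyond the scatter), for iodo in place of chloro. With that single modest step as a guide, a step no larger is expected in this assay, towards a lower number, though the direction is uncertain. The expected step is a 2.5-fold lower number from compound 2 to compound 3 (0.40 log units; beyond the scatter). The estimate for compound 3 is 20000 nM, with an expected range of 7000 nM to 60000 nM.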

Compound 3, half-maximal inhibitory concentration: 19000 nM
The estimate for compound 3 lay 1.1-fold (0.02 log units) above the measured number, within the range that was stated.
By their numbers in this assay, from the lowest: compounds 1 and 3 (each within the scatter of the next); then compound 2.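

Tert-butyl in place of iodo gives a 2.6-fold lower number from compound 2 to compound 3 (0.42 log units; beyond the scatter) in this assay, so the larger count of heavy atoms at this position does not by itself go with a higher number. Against chloro, tert-butyl gives a 1.6-fold higher number from compound 1 to compound 3 (0.20 log units; within the scatter), which leaves compound 2 as the only one of the three set apart from the others by more than the scatter. Nothing shown here accounts for this.

Still open, as far as these compounds go, is how a group of a different kind, such as an amine or a carboxylic acid, would fare on this aromatic carbon.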